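The source may hold more compounds than are shown below. What is called first, only, known or untested is meant among the compounds shown, and "the series" means these compounds.

Compound 1, `O=C1CC(c2nc(-c3cccc(Cl)c3)no2)CN1c1ccccc1Cl`, in an in vitro functional assay on HEK293-A cells for positive allosteric modulation of metabotropic glutamate receptor 5 (Homo sapiens), read by FLIPR and calcium flux; a lower number here means that less compound is needed, a higher number that more compound is needed for the effect: > 10000 nM, a limit.
Compound 2, `Cc1ccc(N2CC(c3nc(-c4cccc(Cl)c4)no3)CC2=O)cc1C`, in this assay: 310 nM.
Compound 3, `O=C1CC(c2nc(-c3cccc(Cl)c3)no2)CN1c1cccc(Cl)c1`, in this assay: > 10000 nM, a limit.

Compound 3 stands at the limit of > 10000 nM in this assay, at which 2 of the 3 values shown sit; its value is a limit, not a number. Compound 4, `COc1cccc(N2CC(c3nc(-c4cccc(Cl)c4)no3)CC2=O)c1`, differs from compound 3 by methoxy in place of chloro on an aromatic carbon. Among the compounds with values here, no measured step exchanges chloro for methoxy. The steps on this nitrogen are an at least 32-fold lower number from compound 1 to compound 2 (1.50 log units; beyond the scatter) and an at least 32-fold higher number from compound 2 to compound 3 (1.50 log units; beyond the scatter), both large, while a step that the two limits leave unreadable from compound 1 to compound 3. Only compound 2 returns a number. Compound 1 also returns only a limit. Methoxy is untested here, so the direction from compound 3 is open and whether compound 4 returns a number is uncertain. Compound 4 is expected at 3000 nM (range 400 nM to 30000 nM), an expected step of an at least 3.3-fold lower number from compound 3 to compound 4 (0.52 log units; beyond the scatter).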

Compound 4, half-maximal effective concentration: > 10000 nM
Compound 4 ended at the assay's limit; the forecaster's own chance of this, stated with the estimate: 50%; middle value at least 3.3-fold (0.52 log units) away from the limit.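

Within the data shown here, neither chloro nor methoxy at this place on the ring gives a number in this assay, so the limit now holds for both groups and compound 2 remains the only compound with a readable value: the limit of > 10000 nM in this assay, at which 3 of the 4 values shown sit. Among these compounds, the one readable comparison is an at least 32-fold higher number from compound 2 to compound 4 (1.50 log units; beyond the scatter). The steps to compound 4 from compound 1 and compound 3 cannot be read, and chloro and methoxy cannot be ranked.

On these data alone, whether a single methyl or an amine at this place returns a number remains open. So does whether compound 2 needs both of its methyl groups.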